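Swapping chloro for methoxy on the phenyl ring

The compounds below may be only part of what the source reports. "The series", "measured", "known", "first", "only" and "open" are said of these compounds alone.

Compound 1 `CC1(C)[C@H]2CC[C@]1(C)N(Cc1cn(-c3cccc(F)c3)nn1)C(=O)C2`: 90 nM
Compound 2 `CC1(C)[C@H]2CC[C@]1(C)N(Cc1cn(-c3ccccc3Br)nn1)C(=O)C2`: 60 nM
Compound 3 `CC1(C)[C@H]2CC[C@]1(C)N(Cc1cn(-c3ccccc3Cl)nn1)C(=O)C2`: 190 nM

In a functional assay on LoVo cells (Homo sapiens) for inhibition, read by MTT assay, with a stated time of 24 h (a lower number here means a stronger inhibitor, a higher number a weaker inhibitor), compound 3 has the highest number of the three, which makes it the weakest inhibitor so far: a 2.1-fold higher number from compound 1 to compound 3 (0.32 log units; beyond the scatter), and a 3.2-fold higher number from compound 2 to compound 3 (0.50 log units; beyond the scatter). Compound 4 `COc1ccccc1-n1cc(CN2C(=O)C[C@@H]3CC[C@@]2(C)C3(C)C)nn1` is still unmeasured. It carries methoxy in place of chloro on an aromatic carbon, ortho to a large group (methoxy in place of chloro on an aromatic carbon). The nearest evidence is the modest step between the two halogens, a 3.2-fold higher number from compound 2 to compound 3 (0.50 log units; beyond the scatter). For the measured compounds named here, no measured compound carries methoxy, so the direction of this change is unknown, and no step beyond the scatter is expected in this assay. For compound 4 the estimated value is 150 nM, with an expected range from 55 nM to 420 nM.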

Compound 4, half-maximal inhibitory concentration: 70 nM
Compound 4: the middle estimate sits 2.1-fold (0.33 log units) above what was measured; measured number inside the range.
By their numbers in this assay, from the lowest: compounds 2, 4 and 1 (each within the scatter of the next); then compound 3.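

In this assay, methoxy in place of chloro on an aromatic carbon, ortho to a large group, gives a clear gain (a 2.7-fold lower number from compound 3 to compound 4 (0.43 log units; beyond the scatter)), so this position accepts more than a halogen. Compound 4 cannot be told apart from the bromo compound (a 1.2-fold higher number from compound 2 to compound 4 (0.07 log units; within the scatter)) or the 3-fluorophenyl compound (a 1.3-fold lower number from compound 1 to compound 4 (0.11 log units; within the scatter)), which leaves the chloro compound as the one that stands apart. Nothing measured here speaks to why chloro differs from bromo and methoxy.

As far as these compounds go, it remains open whether a larger ether such as ethoxy would match methoxy at this position. An amine or a carboxylic acid there is equally untested by the compounds shown.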